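Fluoro step from compound 3: working notes

This account rests on a few compounds, and the source may have more. Where it says the series, first, only, none or still open, it means among the compounds named here.

Measured in an ADME assay on the whole organism (Rattus norvegicus) for pharmacokinetics, at a dose of 5 mg/kg by the oral route; on this read-out lower numbers stand for lower exposure and higher numbers for higher exposure at the dose given:
- compound 1 `COc1cnc(O[C@@H]2C[C@H]3C(=O)N[C@]4(C(=O)NS(=O)(=O)C5(C)CC5)C[C@H]4/C=C\CC[C@@H](C)C[C@@H](C)[C@H](NC(=O)OC(C)(C)C(F)(F)F)C(=O)N3C2)c2ccccc12`: 5290 nM
- compound 2 `CC[C@@H]1C[C@H](C)CC/C=C\[C@@H]2C[C@@]2(C(=O)NS(=O)(=O)C2CC2)NC(=O)[C@@H]2C[C@@H](Oc3ncc(OC)c4ccccc34)CN2C(=O)[C@H]1NC(=O)OC(C)(C)C(F)(F)F`: 2950 nM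
- compound 3 `CC[C@@H]1C[C@H](C)CC/C=C\[C@@H]2C[C@@]2(C(=O)NS(=O)(=O)C2(C)CC2)NC(=O)[C@@H]2C[C@@H](Oc3ncc(OC)c4ccccc34)CN2C(=O)[C@H]1NC(=O)OC(C)(C)C(F)(F)F`: 3030 nM

In this assay compound 3 gives 3030 nM, which lies within the scatter of the values for compound 1 and compound 2. The three compounds therefore cannot be ranked on these numbers.

The next compound is compound 4 `CC[C@@H]1C[C@H](C)CC/C=C\[C@@H]2C[C@@]2(C(=O)NS(=O)(=O)C2(C)CC2)NC(=O)[C@@H]2C[C@@H](Oc3ncc(OC)c4ccc(F)cc34)CN2C(=O)[C@H]1NC(=O)OC(C)(C)C(F)(F)F`, which carries fluoro in place of hydrogen on an aromatic carbon. That carbon belongs to a six-membered aromatic ring of carbon only, part of a fused or bridged system of two rings.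

Two measured steps reach compound 3. One is a 1.7-fold lower number from compound 1 to compound 3 (0.24 log units; within the scatter), a methyl in place of hydrogen on a saturated chain carbon bound to a saturated ring carbon. The other is a 1.0-fold higher number from compound 2 to compound 3 (0.01 log units; within the scatter), a methyl in place of hydrogen on a saturated ring carbon. Both stay within the scatter, but neither touches the aromatic ring, so they bear on this change only indirectly. For the measured compounds named here, no measured compound here carries fluoro on that ring, so the direction of any effect is open. No shift beyond the scatter is expected, and the expected step is a 1.1-fold lower number from compound 3 to compound 4 (0.03 log units; within the scatter).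

For compound 4 the estimated value is 2800 nM, with an expected range of 1200 nM to 6000 nM.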

Compound 4, maximal plasma concentration: 3610 nM
Beside the measured number, compound 4's estimate is 1.3-fold (0.11 log units) below it; low and high end bracket the measured number.
By their numbers in this assay, from the lowest: compounds 2, 3, 4 and 1 (each within the scatter of the next).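

In this assay, the step for fluoro in place of hydrogen on an aromatic carbon of the six-membered aromatic ring of carbon only is a 1.2-fold higher number from compound 3 to compound 4 (0.08 log units; within the scatter), so at this position the change cannot be told apart from repeated measurement. For the compounds shown here, this is the first reading on that ring: the earlier steps covered only methyl in place of hydrogen on saturated carbons, and it now appears that a change on the aromatic part of compound 3 can also leave the maximal plasma concentration within the scatter. Going by these compounds alone, no measurement at hand accounts for the size of this step, and the single pair gives no mechanism for it.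

The compounds shown leave open whether a group other than fluoro on this same aromatic carbon, such as chloro, methoxy, an amine or a carboxylic acid, would move the number beyond the scatter. They also leave open whether fluoro on another carbon of that ring, or the same fluoro on the core of compound 1 or compound 2, would give a step of similar size.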